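The source may report more compounds than this note shows. Statements on the series, on what has been measured and on what is new or still open speak of the compounds shown alone.

Measured in an ADME assay on L6 cells (Rattus norvegicus) for cytotoxicity, read by fluorescence and resazurin assay, with a stated time of 72 h; on this read-out higher numbers stand for lower toxicity in this test and lower numbers for higher toxicity in this test
compound 1 `CC(C)c1ccc(-c2c[nH]cc2C(c2ccc(Cl)cc2Cl)n2ccnc2)cc1` gives 12700 nM
compound 2 `Clc1ccc(C(c2c[nH]cc2-c2ccc(Cl)cc2-c2cccs2)n2ccnc2)c(Cl)c1` gives 4930 nM
compound 3 `Clc1ccc(C(c2c[nH]cc2-c2ccc(Cl)c3ccccc23)n2ccnc2)c(Cl)c1` gives 4900 nM

Compound 1 holds the highest number of the three, beyond the scatter from both compound 2 and compound 3. Compound 4 `CS(=O)(=O)c1ccc(-c2c[nH]cc2C(c2ccc(Cl)cc2Cl)n2ccnc2)cc1` keeps the core of compound 1 and carries methylsulfonyl in place of isopropyl on an aromatic carbon, para to a large group methylsulfonyl in place of isopropyl on an aromatic carbon in the structure. Going by the values given here, no measured pair isolates this change, so the expectation rests on compound 1 at 12700 nM and on judgement. An estimated step of a 2.0-fold higher number from compound 1 to compound 4 (0.29 log units; within the scatter) is expected, a modest rise in this assay that may stay close to the scatter. For compound 4 the expected value is 25000 nM within an estimated range of 9000 nM to 70000 nM as the likely span.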

Compound 4, half-maximal cytotoxic concentration: 68000 nM
Estimate against measurement, compound 4: 2.7-fold (0.43 log units) below; the measured number falls inside the stated range.
By their numbers in this assay, from the lowest: compounds 3 and 2 (each within the scatter of the next); then compound 1; then compound 4.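

In this assay, going by these compounds alone, methylsulfonyl in place of isopropyl on an aromatic carbon, para to a large group, gives a 5.4-fold higher number from compound 1 to compound 4 (0.73 log units; beyond the scatter), the first step that can be read across a single change. The read-out therefore responds to the group at this position, and the swap to methylsulfonyl moves it clearly towards lower toxicity in this test. Nothing at hand gives a cause for the step.

On these data alone, how an amine or a carboxylic acid at this position would read remains open. A single pair also sets no trend across groups.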